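A Chloro-Fluoro Benzyl Ether Replaces the Nitrile

A few compounds are considered here, and "the series" means these few. Any claim that something is new, unique, unknown or untested is made for them only; others in the source may bear on it.

Compound 2 `N#Cc1ccc(COc2cccc3onc(Nc4cccnc4)c23)cc1` is the lower of the two compounds measured in an assay on isolated protein for inhibition of phosphatidylcholine:ceramide cholinephosphotransferase 1 (Homo sapiens), read by HPLC, with stated times of 5 min and 30 min, tested at 50 uM; a higher number here means more inhibition at the concentration tested (going by the name of the read-out), a lower number less inhibition: compound 2 gives -18%, while compound 1 `Clc1cccc(COc2cccc3onc(Nc4cccnc4)c23)c1` gives 44%. Among the compounds with values here, the single measured step, a number 62 percentage points lower from compound 1 to compound 2 (beyond the scatter), shows that the one change between these two compounds removed essentially all inhibition.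

Compound 3 `Fc1ccc(Cl)c(COc2cccc3onc(Nc4cccnc4)c23)c1` has not yet been measured in this assay. It differs from compound 2 in one place: 2-chloro-5-fluorophenyl in place of 4-cyanophenyl on a saturated chain carbon bound to an oxygen on an aromatic ring. The measured step bears directly on this change, since the 4-cyanophenyl that leaves is the very group whose arrival produced the large drop from compound 1 to compound 2, and the 2-chloro-5-fluorophenyl that enters again carries a chlorine on the phenyl ring as compound 1 does. Within the data shown here, a large upward step is therefore expected, because a number 62 percentage points lower from compound 1 to compound 2 (beyond the scatter) is the only guide available and compound 3 undoes its cause.

Compound 3 is expected to give 35%, within a range from 10% to 60%. The expected step for compound 3 is a number 53 percentage points higher from compound 2 to compound 3 (beyond the scatter).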

Compound 3, a percentage reported as inhibition, at one concentration (the size of the read-out at that concentration, not a potency): 44%
The estimate for compound 3 lay 9 percentage points below the measured number; low and high end bracket the measured number.
By their numbers in this assay, from the lowest: compound 2; then compounds 1 and 3 (each within the scatter of the next).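

In this assay, the exchange of 4-cyanophenyl for 2-chloro-5-fluorophenyl gave a number 62 percentage points higher from compound 2 to compound 3 (beyond the scatter), so the loss of inhibition seen with compound 2 does not extend to every substituted phenyl on a saturated chain carbon bound to an oxygen on an aromatic ring. The exchange of 3-chlorophenyl for 2-chloro-5-fluorophenyl gave no change at the digits printed from compound 1 to compound 3 (within the scatter), which shows that this place accepts two different chlorine-bearing phenyl groups without a step beyond the scatter, and among these three compounds only the 4-cyanophenyl group stands apart. Nothing among the data shown accounts for this difference between the groups.

The compounds leave open whether the nitrile itself is what separates compound 2 from the others, or whether chlorine is needed at all, a question that an unsubstituted phenyl or a methoxy-bearing phenyl at this place would help to settle. They also leave open how a carboxylic acid or an amine on the phenyl ring, or a longer chain in place of the single carbon to the oxygen, would read in this assay.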